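Ethoxycarbonyl to methoxycarbonyl on compound 2

This account rests on a few compounds, and the source may have more. Where it says the series, first, only, none or still open, it means among the compounds named here.

Measured in a functional assay on MDA-MB-231 cells (Homo sapiens) for antiproliferative activity, read by MTT assay, with a stated time of 48 h; a lower number here means a stronger inhibitor, a higher number a weaker inhibitor:
- compound 1 `CCOC(=O)/C(=C/c1ccccc1)CN1C(=O)[C@@H](OC)[C@H]1c1ccc(Cl)cc1`: 11100 nM
- compound 2 `CCOC(=O)/C(=C/c1ccccc1)CN1C(=O)[C@@H](OC)[C@H]1c1cccc([N+](=O)[O-])c1`: 14400 nM
- compound 3 `CCOC(=O)/C(=C/c1ccccc1)CN1C(=O)[C@@H](OC)[C@H]1c1ccc(F)cc1`: 14000 nM

Compound 2, at 14400 nM, lies within the scatter of the other two compounds. Compound 4 `COC(=O)/C(=C/c1ccccc1)CN1C(=O)[C@@H](OC)[C@H]1c1cccc([N+](=O)[O-])c1` differs from it in one place: hydrogen in place of methyl on a saturated chain carbon bound to an oxygen next to a carbonyl group. In other words, ethoxycarbonyl becomes methoxycarbonyl. Among the measured compounds shown here, no measured step changes this group. The nearest evidence comes from changes elsewhere on the molecule, a 1.3-fold higher number from compound 1 to compound 2 (0.11 log units; within the scatter) and a 1.0-fold lower number from compound 2 to compound 3 (0.01 log units; within the scatter), and both are small. Any step in this assay is therefore expected to stay within the scatter, with no favoured direction. The estimated change is a 1.1-fold lower number from compound 2 to compound 4 (0.03 log units; within the scatter). The expected value for compound 4 is 13500 nM, with an estimated range of 7000 nM to 26000 nM.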

Compound 4, half-maximal inhibitory concentration: 14400 nM
The estimate for compound 4 lay 1.1-fold (0.03 log units) below the measured number, within the range that was stated.
By their numbers in this assay, from the lowest: compounds 1, 3, 2 and 4 (each within the scatter of the next).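

Among the compounds shown here, changing ethoxycarbonyl to methoxycarbonyl gives the first direct reading at this position: in this assay there is no change at the digits printed from compound 2 to compound 4 (within the scatter). On this compound, then, the ethyl group can be cut to methyl without moving the number. No further measurement bears on this result.

Only this one shortening is shown, so whether a longer chain or a carboxylic acid at this position would hold the number stays open. On these data alone, whether the same change would read alike on compound 1 or compound 3 also stays open.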